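The source may report more compounds than this note shows. Statements on the series, on what has been measured and on what is new or still open speak of the compounds shown alone.

Measured compounds:
compound 1 `CC(=O)c1ccc(OCC(=O)Nc2cccc(NC(=O)c3ccc(N(C)C)cc3)c2)cc1F`, 98 nM
compound 2 `CC(C)(C)c1ccc(C(=O)Nc2cccc(NC(=O)COc3ccc4c(=O)ccoc4c3)c2)cc1`, 34 nM

Both were run in an assay on isolated protein for inhibition of Rho-associated protein kinase 2 (Homo sapiens), read by scintillation counting, radiometric assay and 33P incorporation, with a stated time of 40 min, in the presence of a further agent that is not named here; on this read-out higher numbers stand for weaker inhibition and lower numbers for stronger inhibition. Within the data shown here, compound 2 gives the lower of the two numbers; the gap to compound 1 lies beyond the scatter, though no single-point step links the pair. Compound 3 `COC(=O)c1ccc(C(=O)Nc2cccc(NC(=O)COc3ccc4c(=O)ccoc4c3)c2)cc1` is not yet measured. It differs from compound 2 in one place: methoxycarbonyl in place of tert-butyl on an aromatic carbon. Among the measured compounds shown here, no measured step covers a change of this kind, so the expectation rests on compound 2 alone. The step from compound 2 to compound 3 is expected to be modest, toward a somewhat higher number, a 1.8-fold higher number from compound 2 to compound 3 (0.25 log units; within the scatter). Compound 3 is estimated at 60 nM, within a range from 20 nM to 200 nM.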

Compound 3, half-maximal inhibitory concentration: 29 nM
Beside the measured number, compound 3's estimate is 2.1-fold (0.32 log units) above it; low and high end bracket the measured number.
By their numbers in this assay, from the lowest: compounds 3 and 2 (each within the scatter of the next); then compound 1.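

Read in this assay with the shared core held fixed, methoxycarbonyl in place of tert-butyl on this aromatic carbon gives a 1.2-fold lower number from compound 2 to compound 3 (0.07 log units; within the scatter), a step within the scatter. At this position, a group with 2 hydrogen-bond acceptors and one with 0, each of 4 heavy atoms, are not told apart on this read-out. Nothing available accounts for this result.

On these data alone, whether a carboxylic acid, an amine or a longer chain at this position would keep the number stays open. Also open, as far as these compounds go, is whether the same swap would behave alike on the core of compound 1.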